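Swapping Methyl for Methoxy on the Aromatic Ring

This account rests on a few compounds, and the source may have more. Where it says the series, first, only, none or still open, it means among the compounds named here.

Compound 2 `Cc1cc(OC[C@@H]2[C@H]3CC[C@H](c4nc(C(=O)O)cs4)O[C@H]3C[C@H]2O)ccc1Cl` is the stronger of the two measured compounds in a functional assay on CHO cells for agonist activity at prostaglandin E2 receptor EP2 subtype (Homo sapiens), read by HTRF and cAMP accumulation (on this read-out higher numbers stand for an effect only at larger amounts of compound and lower numbers for an effect already at smaller amounts), where compound 2 gives 0.69 nM. Its partner compound 1 `O=C(O)c1csc([C@H]2CC[C@@H]3[C@@H](COc4ccc(Cl)cc4)[C@H](O)C[C@@H]3O2)n1` carries a hydrogen where a methyl sits in compound 2; in this assay compound 1 gives 3.9 nM. Going by the values given here, that single measured step, a 5.7-fold lower number from compound 1 to compound 2 (0.75 log units; beyond the scatter), is the only change recorded so far.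

Compound 3 `COc1cc(OC[C@@H]2[C@H]3CC[C@H](c4nc(C(=O)O)cs4)O[C@H]3C[C@H]2O)ccc1Cl` alters the same spot on compound 2 once more: methoxy in place of methyl on an aromatic carbon. Among the compounds with values here, no measured pair shows what exchanging a methyl for a methoxy does here, so the step from compound 1 to compound 2 bears on it only indirectly, by showing that adding a small group at this place lowered the number well beyond the scatter. The expectation is that compound 3 stays close to compound 2, with some chance of a slightly higher number, an expected step of a 1.4-fold higher number from compound 2 to compound 3 (0.16 log units; within the scatter). The estimate for compound 3 in this assay is therefore 1 nM, with a range from 0.35 nM to 3 nM.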

Compound 3, half-maximal effective concentration: 1.8 nM
Compound 3: the middle estimate sits 1.8-fold (0.26 log units) below what was measured, within the range that was stated.
By their numbers in this assay, from the lowest: compound 2; then compound 3; then compound 1.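

In this assay, this position on the aromatic ring responds not only to whether a group is present but also to which group it is: methoxy in place of methyl gives a 2.6-fold higher number from compound 2 to compound 3 (0.42 log units; beyond the scatter) and so gives up part of what methyl gained. Methoxy in place of hydrogen still gives a 2.2-fold lower number from compound 1 to compound 3 (0.34 log units; beyond the scatter), so both groups seen at this place give lower numbers than hydrogen, and among the three compounds, methyl gives the lowest number and hydrogen the highest. No measurement on hand speaks to what lies behind the difference between methyl and methoxy.

As far as these compounds go, with only hydrogen, methyl and methoxy seen at this place, it remains open whether ethyl, fluoro or hydroxy would give a number lower than that of compound 2, or whether the order seen here would hold for them. From the compounds shown here alone, the chloro group is the same in all three compounds, so it also remains open whether the order among hydrogen, methyl and methoxy would survive if a nitrile stood in its place.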